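Amide aryl variation on the dodecyl tetrazole amides

A few compounds are considered here, and "the series" means these few. Any claim that something is new, unique, unknown or untested is made for them only; others in the source may bear on it.

Measured so far:
compound 1, `CCCCCCCCCCCCn1nnc(C(NC(=O)c2ccccc2)c2ccccc2)n1`: 350 nM in an assay on microsomes from liver for inhibition of sterol O-acyltransferase 1 (Rattus norvegicus); a lower number here means a stronger inhibitor, a higher number a weaker inhibitor
compound 2, `CCCCCCCCCCCCn1nnnc1C(NC(=O)c1c(C)cccc1C)c1ccccc1`: 180 nM in this assay
compound 3, `CCCCCCCCCCCCn1nnnc1C(NC(=O)c1ccc(F)cc1F)c1ccccc1`: 380 nM in this assay

Compound 3 gives the highest number of the three. Against compound 1 the gap is within the scatter, so the two cannot be ordered. Against compound 2 the gap is real: a 2.1-fold higher number from compound 2 to compound 3 (0.32 log units; beyond the scatter), a modest step on the aryl attached to the carbonyl carbon.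

Compound 4, `CCCCCCCCCCCCn1nnnc1C(NC(=O)c1cccc([N+](=O)[O-])c1)c1ccccc1`, is not yet measured. It differs from compound 3 in one place: 3-nitrophenyl in place of 2,4-difluorophenyl on a carbonyl carbon.

Going by the values given here, only one measured step touches this position, the exchange of the aryl on the carbonyl carbon from compound 2 to compound 3, and it was modest. Among the compounds with values here, there is no measured pair that tells how a nitro-bearing aryl behaves here, and no pair that sets a direction for a change from a difluorophenyl. The expectation is therefore a step of modest size at most, with no firm direction, and possibly none beyond the scatter. Compound 4 is expected to give 300 nM, in the range 140 nM to 700 nM. The expected step is a 1.3-fold lower number from compound 3 to compound 4 (0.10 log units; within the scatter).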

Compound 4, half-maximal inhibitory concentration: 190 nM
Compound 4: the middle estimate sits 1.6-fold (0.20 log units) above what was measured; low and high end bracket the measured number.
By their numbers in this assay, from the lowest: compounds 2, 4, 1 and 3 (each within the scatter of the next, the first and the last beyond it).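

In this assay the 3-nitrophenyl on the carbonyl carbon shows no step beyond the scatter against either aryl with which it can be compared (a 2.0-fold lower number from compound 3 to compound 4 (0.30 log units; within the scatter)) (a 1.1-fold higher number from compound 2 to compound 4 (0.02 log units; within the scatter)). Going by these compounds alone, this position therefore takes an aryl carrying a nitro group and its hydrogen-bond acceptors without a clear change in the number, a point that the fluorine and methyl substituents of the earlier compounds could not show. The one gap beyond the scatter among these aryls remains the one from the 2,6-dimethylphenyl to the 2,4-difluorophenyl (a 2.1-fold higher number from compound 2 to compound 3 (0.32 log units; beyond the scatter)), and compound 4 cannot be assigned to either end of it. No measurement in hand bears on why the numbers fall as they do.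

Open, as far as these compounds go, is whether the nitro group itself matters here, or whether an amine or a carboxylic acid at the same place on the aryl would give a number that stays as close. Also open, from the compounds shown here alone, is whether the same tolerance at the carbonyl carbon would hold with a shorter chain in place of the dodecyl chain.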